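The source may report more compounds than this note shows. Statements on the series, on what has been measured and on what is new or still open speak of the compounds shown alone.

The compounds measured so far, with their values in a functional assay on HCT-116 cells (Homo sapiens) for cytotoxicity, read by MTT assay, with a stated time of 48 h; on this read-out lower numbers stand for stronger inhibition and higher numbers for weaker inhibition:

Compound 1, `CCc1ccc(C2CN(C)[C@]3(C(=O)Nc4ccc(Br)cc43)[C@]23NC(=S)N(c2ccc(F)c(Cl)c2)C3=O)cc1`: compound 1 gives 11600 nM.
Compound 2, `CC(C)Oc1ccc(C2CN(C)[C@]3(C(=O)Nc4ccc(Br)cc43)[C@]23NC(=S)N(c2ccc(F)c(Cl)c2)C3=O)cc1`: compound 2 gives 38800 nM.
Compound 3, `CCOc1ccc(N2C(=O)[C@@]3(NC2=S)C(c2ccc(Cl)cc2)CN(C)[C@]32C(=O)Nc3ccc(Br)cc32)cc1`: compound 3 reaches only (the limit of >= 50000 nM in this assay, at which 1 of the 3 values shown sits), which is a limit of the assay and not a number, and compound 3 is reported as >= 50000 nM.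

Compound 2 therefore holds the highest of the two numbers that this assay has produced, standing a 3.3-fold higher number from compound 1 to compound 2 (0.52 log units; beyond the scatter) away from compound 1, the nearest measured neighbour; the third value shown for compound 3 is a limit and cannot be ranked.

Compound 4, `CC(C)Oc1ccc(C2CN(C)[C@]3(C(=O)Nc4ccccc43)[C@]23NC(=S)N(c2ccc(F)c(Cl)c2)C3=O)cc1`, is the compound still to be measured. It differs from compound 2 in one place: hydrogen in place of bromo on an aromatic carbon. Within the data shown here, no measured step touches this position; the only measured step, a 3.3-fold higher number from compound 1 to compound 2 (0.52 log units; beyond the scatter), concerns the substituent on a different aromatic ring. Nothing in the shown data therefore predicts the direction of the change, and the expectation is a step near the scatter, if anything toward a higher number. Compound 4 is expected to give 42000 nM, within a range of 14000 nM to 130000 nM, meaning an estimated step of a 1.1-fold higher number from compound 2 to compound 4 (0.03 log units; within the scatter).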

Compound 4, half-maximal inhibitory concentration: 8550 nM
For compound 4 the middle estimate is 4.9-fold (0.69 log units) above the measured one; the measured number lies below the stated range.
By their numbers in this assay, from the lowest: compounds 4 and 1 (each within the scatter of the next); then compound 2. At a limit, above all of these: compound 3.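

In this assay, hydrogen in place of bromo on this aromatic carbon gives a 4.5-fold lower number from compound 2 to compound 4 (0.66 log units; beyond the scatter), so the position, which carries bromo in compounds 1, 2 and 3 alike, does bear on the read-out. Bromo is thus not required for activity at this level in the isopropoxy series: the compound without it has the lower number, and the step lies beyond the scatter. Nothing among the measurements shown gives a reason for this change.

What the compounds shown leave open is whether the same change would lower the number in the ethyl compound, compound 1. They also leave open what a methoxy group, an amine or a carboxylic acid would do on this aromatic carbon.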